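The source may hold more compounds than are shown below. What is called first, only, known or untested is meant among the compounds shown, and "the series" means these compounds.

In a functional assay on ACHN cells (Homo sapiens) for inhibition, read by sulforhodamine B assay, with a stated time of 48 h (a higher number here means a weaker inhibitor of growth, a lower number a stronger inhibitor of growth), compound 1 `COc1cc(-c2cc(/C=C/C(=O)c3ccc(Cl)c(Cl)c3)[nH]n2)cc(OC)c1OC` gives > 100000 nM, which is a limit of the assay and not a number; compound 1 stands at the limit of > 100000 nM in this assay, at which 1 of the 2 values shown sits. Going by the values given here, compound 2 `COc1ccc(-c2cc(/C=C/C(=O)c3ccc(N)cc3)[nH]n2)cc1OC` is the only compound with a numeric value, giving 3290 nM in this assay. Compound 3 `COc1ccc(C(=O)/C=C/c2cc(-c3cc(OC)c(OC)c(OC)c3)n[nH]2)cc1OC` differs from compound 1 by 3,4-dimethoxyphenyl in place of 3,4-dichlorophenyl on a carbonyl carbon. Among the compounds with values here, no measured step matches this change. For compound 3 a step beyond the scatter is expected in this assay, toward stronger growth inhibition, an at least 5.0-fold lower number from compound 1 to compound 3 (0.69 log units; beyond the scatter). Compound 3 is expected to give 20000 nM in this assay, within 5000 nM to 100000 nM.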

Compound 3, concentration for total growth inhibition: 3090 nM
Compound 3: the middle estimate sits 6.5-fold (0.81 log units) above what was measured, outside the stated range (below it).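

In this assay, 3,4-dimethoxyphenyl in place of 3,4-dichlorophenyl on a carbonyl carbon gives an at least 32-fold lower number from compound 1 to compound 3 (1.51 log units; beyond the scatter), so growth inhibition in this series is sensitive to the group at this position. Compound 1 gives > 100000 nM, a limit of the assay and not a number. The step is therefore a minimum and its full size cannot be read: the limit of > 100000 nM in this assay, at which 1 of the 3 values shown sits.

The compounds shown do not separate the gain from the two methoxy groups from the loss of the two chlorine atoms. From the compounds shown here alone, how a phenyl ring carrying one methoxy group, an amine or a carboxylic acid would read in this assay also stays open.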